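Fluorine Shift on the Ring Nitrogen: Compound 1 to Compound 3

The compounds below may be only part of what the source reports. "The series", "measured", "known", "first", "only" and "open" are said of these compounds alone.

Measured so far:
compound 1, `O=C(NCCCCc1ccccc1)c1cccc(C2SCC(=O)N2c2cccc(F)c2)c1`: 94%
compound 2, `CCOc1ccccc1N1C(=O)C(C)SC1c1cccc(C(=O)NCCCCc2ccccc2)c1`: 94%

In a functional assay on HOS-TE85 cells (Homo sapiens) for inhibition, read by CCK-8 assay, with a stated time of 72 h, tested at 1 uM (on this read-out lower numbers stand for less inhibition and higher numbers for more inhibition at the one concentration tested (going by the name of the read-out)), compound 1 gives 94%, and compound 2 gives 94% in this assay. Compound 1 therefore stands level with compound 2 at the digits shown; the two values lie within the usual scatter, so no order can be read between them, and both show strong inhibition at the single concentration tested.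

Compound 3, `O=C(NCCCCc1ccccc1)c1cccc(C2SCC(=O)N2c2ccccc2F)c1`, has not yet been measured in this assay. It differs from compound 1 in one place: 2-fluorophenyl in place of 3-fluorophenyl on an amide-type nitrogen in a ring. For the measured compounds named here, no measured pair differs in this way alone, so there is no measured step to lean on for this change. Since compound 1 gives 94% in this assay, compound 3 is expected to stay near that level, and the step from compound 1 to compound 3 is expected to be a number 4 percentage points lower from compound 1 to compound 3 (within the scatter), none beyond the scatter. Compound 3 is estimated at 90% in this assay, with a range from 75% to 98%.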

Compound 3, a percentage reported as inhibition, at one concentration (the size of the read-out at that concentration, not a potency): 95%
For compound 3 the middle estimate is 5 percentage points below the measured one, and the stated range covers the measured number.
By their numbers in this assay, from the lowest: compounds 1, 2 and 3 (each within the scatter of the next).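

In this assay, putting 2-fluorophenyl in place of 3-fluorophenyl on the amide-type nitrogen in a ring gives a number 1 percentage points higher from compound 1 to compound 3 (within the scatter), the first single-change comparison among these compounds. At this one concentration, the fluorine can therefore sit at either of these two places on the phenyl ring with no difference that can be read. Nothing available explains why the two fluorophenyl groups read alike.

The compounds shown leave open whether a different group on this nitrogen, such as a pyridine ring or a phenyl ring carrying a carboxylic acid, would hold the same level. Going by these compounds, a reading at one concentration is not a potency, so it also remains open whether compound 1 and compound 3 would separate at lower concentrations.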